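The source may hold more compounds than are shown below. What is called first, only, known or untested is meant among the compounds shown, and "the series" means these compounds.

Compound 1 `CCOC(=O)c1cnn(-c2nc(-c3ccc(OC)cc3)c(C#N)c(=O)n2C)c1N`: 68 ug/mL
Compound 2 `CCOC(=O)c1cnn(-c2nc(-c3ccccc3F)c(C#N)c(=O)n2C)c1N`: 94 ug/mL

Both numbers come from a functional assay on microsomes for inhibition, with a stated time of 1 h; a higher number here means a weaker inhibitor, a lower number a stronger inhibitor. With only these two results available, compound 2 stands level with compound 1 within the scatter of repeat measurements, and neither can be ranked above the other.

The next compound to be tested is compound 3 `CCOC(=O)c1cnn(-c2nc(-c3cccc(OC)c3OC)c(C#N)c(=O)n2C)c1N`. It keeps the shared core and changes a single group on an aromatic carbon, the one ortho to a cyano group: 2,3-dimethoxyphenyl in place of 2-fluorophenyl on an aromatic carbon. In words, 2,3-dimethoxyphenyl takes the place of 2-fluorophenyl.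

Within the data shown here, one measured step bears on this, since it changed the group on that same carbon. Replacing 4-methoxyphenyl with 2-fluorophenyl gave a 1.4-fold higher number from compound 1 to compound 2 (0.14 log units; within the scatter), a step within the scatter. Among the measured compounds shown here, that small step is the only guide, and no measured compound carries 2,3-dimethoxyphenyl. No shift beyond the scatter is therefore expected in this assay, and no direction can be claimed. The expected change is a 1.2-fold lower number from compound 2 to compound 3 (0.07 log units; within the scatter). For compound 3 the estimate is 80 ug/mL, with an expected range from 35 ug/mL to 180 ug/mL.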

Compound 3, half-maximal inhibitory concentration: 57 ug/mL
The estimate for compound 3 lay 1.4-fold (0.15 log units) above the measured number, and the stated range covers the measured number.
By their numbers in this assay, from the lowest: compounds 3, 1 and 2 (each within the scatter of the next).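

At the aromatic carbon ortho to a cyano group, 2,3-dimethoxyphenyl brings 10 heavy atoms and 2 hydrogen-bond acceptors where 2-fluorophenyl has 7 heavy atoms and 0 hydrogen-bond acceptors, yet this assay shows only a 1.6-fold lower number from compound 2 to compound 3 (0.22 log units; within the scatter) for this change. Set against the single-methoxy group, the same ring gives a 1.2-fold lower number from compound 1 to compound 3 (0.08 log units; within the scatter) and so also stays within the scatter of repeat measurements. All three compounds therefore read alike, and a second methoxy group, a fluorine or a shift in where the ring carries its groups has not moved the number measurably, though no data at hand explain why these groups read alike.

As far as these compounds go, all three groups at this carbon are still phenyl rings bearing fluorine or methoxy, so it remains open whether something quite different there, such as an amine, a carboxylic acid or a longer alkyl chain, would move the number beyond the scatter. The compounds shown also say nothing about whether changes elsewhere on the shared core would matter more than changes at this position.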